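Benzylsulfanyl replacing propoxy: a cytotoxicity limit in question

This account rests on a few compounds, and the source may have more. Where it says the series, first, only, none or still open, it means among the compounds named here.

Compound 1 `Nc1nc(NC2CCCC2)c2ncn(/C=C3/CC3(CO)CO)c2n1`: > 300000 nM (a limit)
Compound 2 `CCCCCOc1nc(N)nc2c1ncn2/C=C1/CC1(CO)CO`: 259000 nM
Compound 3 `CCCOc1nc(N)nc2c1ncn2/C=C1/CC1(CO)CO`: > 300000 nM (a limit)

In an ADME assay on HFF cells (Homo sapiens) for cytotoxicity, with a stated time of 8 days (on this read-out higher numbers stand for lower toxicity in this test and lower numbers for higher toxicity in this test), compound 3 gives > 300000 nM, which is a limit and not a number. It sits with compound 1 at the limit of > 300000 nM in this assay, at which 2 of the 3 values shown sit. Among the measured compounds shown here, the only true number comes from compound 2, at 259000 nM.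

Compound 4 `Nc1nc(SCc2ccccc2)c2ncn(/C=C3/CC3(CO)CO)c2n1` carries benzylsulfanyl in place of propoxy on an aromatic carbon. The measured steps that bear on this change alter the group at this same carbon or the length of its chain. One is an at least 1.1-fold lower number from compound 1 to compound 2 (0.06 log units; that floor lies within the scatter). Another is a step that the two limits leave unreadable from compound 1 to compound 3. The third is an at least 1.1-fold higher number from compound 2 to compound 3 (0.06 log units; that floor lies within the scatter). For the measured compounds named here, none of them shows a change beyond the scatter, but no measured compound carries benzylsulfanyl, so they offer only weak guidance. A small step to a lower number is expected, and the estimated step is an at least 1.3-fold lower number from compound 3 to compound 4 (0.13 log units; that floor lies within the scatter). The value estimated for compound 4 in this assay is 220000 nM, with an expected range from 90000 nM to 300000 nM.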

Compound 4, half-maximal cytotoxic concentration: > 300000 nM
Compound 4 gave a limit, no number (the forecaster's own chance of this, stated with the estimate: 50%); middle value at least 1.3-fold (0.13 log units) from the limit.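

In this assay compound 4 gives > 300000 nM, which is a limit. Benzylsulfanyl, with its sulfur and its six-membered aromatic ring, therefore leaves this aromatic carbon at the same limit as the smaller propoxy and cyclopentylamino groups: the limit of > 300000 nM in this assay, at which 3 of the 4 values shown sit. Among the compounds shown here, the only step that can be read is an at least 1.1-fold higher number from compound 2 to compound 4 (0.06 log units; that floor lies within the scatter), so benzylsulfanyl in place of pentyloxy shows no change beyond the scatter, while the steps from compound 1 and compound 3 to compound 4 cannot be read, as both ends are limits.

The compounds shown leave open how compound 1, compound 3 and compound 4 stand relative to one another beyond the limit. They also leave open whether the sulfur or the benzyl part matters at this carbon, a question on which a benzyloxy group would bear.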